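A few compounds are considered here, and "the series" means these few. Any claim that something is new, unique, unknown or untested is made for them only; others in the source may bear on it.

In a functional assay on PANC-1 cells (Homo sapiens) for inhibition, read by MTT assay, with a stated time of 72 h (on this read-out higher numbers stand for weaker inhibition and lower numbers for stronger inhibition), compound 2 `O=C(Nc1cc(Cl)cc2cccnc12)c1ncccn1` gives 4670 nM, the highest of the three numbers recorded. Within the data shown here, compound 1 `Cc1cnc(C(=O)Nc2cc(Cl)cc3cccnc23)cn1` gives 1770 nM, and the only single-point step measured, a 2.6-fold higher number from compound 1 to compound 2 (0.42 log units; beyond the scatter), is modest in size. Compound 3 `O=C(Nc1cc(OCCF)cc2cccnc12)c1cnccn1` gives 530 nM; it differs from compound 2 in two places, so its much lower number cannot be assigned to either change alone. Compound 4 `NCCOc1cc(NC(=O)c2ncccn2)c2ncccc2c1` carries 2-aminoethoxy in place of chloro on an aromatic carbon. Among the measured compounds shown here, no measured step bears directly on this change; the one step measured concerns the group on the carbonyl carbon and is modest. Compound 3, which likewise carries an ether chain in place of chloro, shows a number far lower than compound 2, yet it also carries a different group on the carbonyl carbon, so its weight as a guide is limited. The number expected for compound 4 in this assay is 2000 nM, within a range from 600 nM to 6500 nM. This estimate means an expected step of a 2.3-fold lower number from compound 2 to compound 4 (0.37 log units; beyond the scatter).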

Compound 4, half-maximal inhibitory concentration: > 10000 nM
Compound 4: only a limit was reported (the forecaster's own chance of this, stated with the estimate: 5%); middle value at least 5.0-fold (0.69 log units) from the limit.
By their numbers in this assay, from the lowest: compound 3; then compound 1; then compound 2. At a limit, above all of these: compound 4.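

With pyrimidin-2-yl held fixed on the carbonyl carbon, 2-aminoethoxy in place of chloro, on the aromatic carbon para to a fused ring, gives an at least 2.1-fold higher number from compound 2 to compound 4 (0.33 log units; beyond the scatter) in this assay. Among these compounds, this is the first single-change reading at this position, and it shows that the position is not indifferent to its substituent and that this ether chain does not lower the number. Compound 4 gives > 10000 nM, which is a limit, so the step has a floor but no measured size.

As far as these compounds go, how far compound 4 lies past that limit remains open: the limit of > 10000 nM in this assay, at which 1 of the 4 values shown sits. Also open, from the compounds shown here alone, is whether the terminal amine or the ether chain as a whole drives the step, a question that a 2-hydroxyethoxy or methoxy group at this place could address.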